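A few compounds are considered here, and "the series" means these few. Any claim that something is new, unique, unknown or untested is made for them only; others in the source may bear on it.

Measured compounds:
compound 1 `O=C1NCCN1CCN1CCC(n2cc(-c3ccc(F)cc3)c3ccccc32)CC1`, 6.3 nM
compound 2 `Cc1cccc2c(-c3ccc(F)cc3)cn(C3CCN(CCN4CCNC4=O)CC3)c12`, 23 nM
compound 3 `Cc1ccc2c(c1)c(-c1ccc(F)cc1)cn2C1=CCN(CCN2CCNC2=O)CC1`, 24 nM

In an assay on cell membranes for displacement of a labelled ligand from Alpha-1A adrenergic receptor (Rattus norvegicus) (a higher number here means a weaker inhibitor, a lower number a stronger inhibitor), compound 1 gives 6.3 nM. Compound 2 differs from it by methyl in place of hydrogen on an aromatic carbon, and this gave a 3.7-fold higher number from compound 1 to compound 2 (0.56 log units; beyond the scatter). Compound 3 gives 24 nM in this assay; it and compound 2 lie within the scatter of each other, and both sit beyond the scatter from compound 1. The difference between the core of compound 3 and the core of compound 1 is not broken down here.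

Compound 4 `Cc1ccc2c(c1)c(-c1ccc(F)cc1)c(C)n2C1=CCN(CCN2CCNC2=O)CC1` has not yet been measured. It differs from compound 3 by methyl in place of hydrogen on an aromatic carbon. The change from compound 1 to compound 2 is the same kind of change, but it is not the same: there the methyl entered on a six-membered aromatic ring of carbon only, ortho to a fused ring and meta to a fused ring, whereas here it enters on a five-membered aromatic ring with one nitrogen, next to the ring nitrogen and next to the ring atom that bears the 4-fluorophenyl group. For the measured compounds named here, because the only precedent is a 3.7-fold higher number from compound 1 to compound 2 (0.56 log units; beyond the scatter), a step of similar size is expected, tempered for the different surroundings; the step expected from compound 3 to compound 4 is a 2.1-fold higher number from compound 3 to compound 4 (0.32 log units; beyond the scatter). Compound 4 is therefore estimated at 50 nM, between 18 nM and 150 nM.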

Compound 4, half-maximal inhibitory concentration: 1000 nM
Compound 4: the middle estimate sits 20-fold (1.30 log units) below what was measured; measured number above the stated range.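

In this assay, methyl in place of hydrogen on the aromatic carbon gave a 42-fold higher number from compound 3 to compound 4 (1.62 log units; beyond the scatter), and this step does not match the earlier instance of the change: the same change on two cores in this assay, a 3.7-fold higher number (0.56 log units; beyond the scatter) from compound 1 to compound 2 and a 42-fold higher number (1.62 log units; beyond the scatter) from compound 3 to compound 4, 11-fold (1.06 log units) apart, beyond the scatter of two such steps The size of the step therefore did not carry over from one core to the other, although the number rose in both pairs. These two pairs do not show whether the gap follows from where the methyl sits, on the five-membered aromatic ring with 1 nitrogen rather than on the six-membered ring of carbon only, or from the rest of the core, as the pairs differ in both.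

The compounds shown leave open whether methyl at this same place on the core of compound 1 would give a step as large as the one seen here. They also leave open whether a smaller fluorine atom or a larger ethyl group at that carbon would give a similar rise.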